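The compounds below may be only part of what the source reports. "The series", "measured", "known", "first", "only" and "open" are said of these compounds alone.

Measured so far:
compound 1 `Nc1nc2[nH]c(CCCCCCC(=O)N[C@@H](CCC(=O)O)C(=O)O)cc2c(=O)[nH]1`: 10.6 nM
compound 2 `Nc1nc2[nH]c(CCCCCC(=O)O)cc2c(=O)[nH]1`: > 1000 nM

In a functional assay on D4 cells (Cricetulus griseus) for inhibition, read by CellTiter-Blue, with a stated time of 96 h (on this read-out higher numbers stand for weaker inhibition and lower numbers for stronger inhibition), compound 1 gives 10.6 nM. Compound 2 reaches only a limit of this assay, > 1000 nM, not a number. Among the two values shown, (the limit of > 1000 nM in this assay, at which 1 of the 2 values shown sits), so compound 2 stands at the weak end. Compound 3 `Nc1nc2[nH]c(CCCCCCCCC(=O)O)cc2c(=O)[nH]1` differs from compound 2 by 3-carboxypropyl in place of carboxy on a saturated chain carbon, five bonds along the chain from an aromatic carbon. In this assay the expected step is a step that the limit leaves unreadable from compound 2 to compound 3, that is, nothing beyond the usual scatter, since compound 2 already sits at the limit. Compound 3 is estimated at 2000 nM, within a range from 400 nM to 10000 nM.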

Compound 3, half-maximal inhibitory concentration: > 1000 nM
Compound 3 was reported as a limit; the forecaster's own chance of this, stated with the estimate: 70%; the middle value is on the limit's open side.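

Compound 2 and compound 3 both stop at a limit in this assay, not at a number, so no step can be read between them: the limit of > 1000 nM in this assay, at which 2 of the 3 values shown sit. The compounds shown leave open whether 3-carboxypropyl in place of carboxy changes inhibition at all.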